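Chloro Replacing Hydrogen in a Cytotoxicity Series

This account rests on a few compounds, and the source may have more. Where it says the series, first, only, none or still open, it means among the compounds named here.

In a functional assay on SK-N-SH cells (Homo sapiens) for cytotoxicity, read by MTT assay, with a stated time of 48 h (on this read-out lower numbers stand for stronger inhibition and higher numbers for weaker inhibition), compound 1 `O=C1Nc2ccccc2C1(c1c(-c2ccccc2)[nH]c2ccccc12)c1c(-c2ccccc2)[nH]c2ccccc12` gives 9600 nM.
Compound 2 `COC(=O)c1ccc2[nH]cc(C3(c4c[nH]c5ccc(C(=O)OC)cc45)C(=O)Nc4ccccc43)c2c1` gives 980 nM in this assay.
Compound 3 `O=C1Nc2ccc(Cl)cc2C1(c1c(-c2ccccc2)[nH]c2ccccc12)c1c(-c2ccccc2)[nH]c2ccccc12` gives only a limit of the assay in this assay, > 100000 nM.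

Compound 2 has the lowest of the two numbers; the difference between the core of compound 1 and that of compound 2 is not broken down here. One measured step exists: chloro in place of hydrogen on an aromatic carbon, and in this assay it gave an at least 10-fold higher number from compound 1 to compound 3 (1.01 log units; beyond the scatter). The value of compound 3 sits at the limit of > 100000 nM in this assay, at which 1 of the 3 values shown sits, so the step is known only as a minimum.

Compound 4 `COC(=O)c1ccc2[nH]cc(C3(c4c[nH]c5ccc(C(=O)OC)cc45)C(=O)Nc4ccc(Cl)cc43)c2c1` is not yet measured. It differs from compound 2 by chloro in place of hydrogen on an aromatic carbon, the same change as that from compound 1 to compound 3, at the same kind of place. Because compound 1 to compound 3 showed an at least 10-fold higher number from compound 1 to compound 3 (1.01 log units; beyond the scatter), a weakening of similar size is expected here, a 15-fold higher number from compound 2 to compound 4 (1.18 log units; beyond the scatter). Compound 4 is therefore estimated at 15000 nM in this assay, between 3000 nM and 100000 nM.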

Compound 4, half-maximal inhibitory concentration: 9900 nM
The estimate for compound 4 lay 1.5-fold (0.18 log units) above the measured number, within the range that was stated.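

On the core of compound 2, chloro in place of hydrogen on an aromatic carbon gave a 10-fold higher number from compound 2 to compound 4 (1.00 log units; beyond the scatter) in this assay, so the number rose on this core, as it did on the core of compound 1. For that earlier pair, compound 3 gives > 100000 nM, which is a limit of the assay and not a number. The direction of the change therefore carried over between these two cores, but whether its size carried over stays unknown, and two cores are too few to make a rule for the whole series: the same change on two cores in this assay, an at least 10-fold higher number (1.01 log units; beyond the scatter) from compound 1 to compound 3 and a 10-fold higher number (1.00 log units; beyond the scatter) from compound 2 to compound 4; the limit leaves it open whether they differ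

The compounds shown have only hydrogen or chloro at this place, so it remains open how fluoro, an amine or a carboxylic acid there would read in this assay. They also leave open whether chloro on another carbon of the same ring would give a step of similar size.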